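The source may report more compounds than this note shows. Statements on the series, on what has been measured and on what is new or still open speak of the compounds shown alone.

Measured so far in a functional assay on HGC-27 cells (Homo sapiens) for inhibition, read by MTT assay, with a stated time of 72 h; a higher number here means a weaker inhibitor, a lower number a stronger inhibitor:
compound 1, `Cc1cc(N2CC[C@@H](C)[C@@H](N(C)c3ncnc4[nH]ccc34)C2)n2nc(SCc3cc(Cl)ccc3Cl)nc2n1`, 19200 nM;
compound 2, `Cc1cc(N2CC[C@@H](C)[C@@H](N(C)c3ncnc4[nH]ccc34)C2)n2nc(SCc3ccccc3Br)nc2n1`, 21300 nM.

Compound 2 sits alongside compound 1 on these numbers, the step of a 1.1-fold higher number from compound 1 to compound 2 (0.05 log units; within the scatter) falling within the scatter. Compound 3, `Cc1cc(N2CC[C@@H](C)[C@@H](N(C)c3ncnc4[nH]ccc34)C2)n2nc(SCc3ccccc3)nc2n1`, differs from compound 2 by hydrogen in place of bromo on an aromatic carbon. For the measured compounds named here, the only step that bears on this change is that from compound 1 to compound 2, which was within the scatter, so the expectation for this assay is no step beyond the scatter, with the number if anything a little higher. For compound 3 the estimated value is 26000 nM, range 10000 nM to 65000 nM. The expected step is a 1.2-fold higher number from compound 2 to compound 3 (0.09 log units; within the scatter).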

Compound 3, half-maximal inhibitory concentration: 13900 nM
For compound 3 the middle estimate is 1.9-fold (0.27 log units) above the measured one; measured number inside the range.
By their numbers in this assay, from the lowest: compounds 3, 1 and 2 (each within the scatter of the next).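

In this assay hydrogen in place of bromo on this aromatic carbon stays within the scatter (a 1.5-fold lower number from compound 2 to compound 3 (0.19 log units; within the scatter)), and phenyl in place of 2,5-dichlorophenyl does too (a 1.4-fold lower number from compound 1 to compound 3 (0.14 log units; within the scatter)). The ring without any halogen therefore reads the same as both halogenated rings, so among these three compounds, halogen on this ring makes no difference beyond the scatter. Nothing measured bears on the reason for this.

Still open, on these data alone, is whether an amine or a carboxylic acid on this ring moves the number beyond the scatter. The same question stands for a longer chain between the sulfur and the phenyl.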